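The source may hold more compounds than are shown below. What is called first, only, known or untested is meant among the compounds shown, and "the series" means these compounds.

Compound 1 `CN1CCN(Cc2nnc(-c3cc(S(N)(=O)=O)c(SCc4ccccc4)cc3Cl)o2)CC1` is measured in a functional assay on MCF7 cells (Homo sapiens) for cytotoxicity, read by MTT assay, with a stated time of 72 h (a lower number here means a stronger inhibitor, a higher number a weaker inhibitor), where compound 1 gives 75000 nM. For the measured compounds named here, the only other measured compound, compound 2 `[N-]=[N+]=NCc1nnc(-c2cc(S(N)(=O)=O)c(SCc3ccccc3)cc2Cl)o1`, gives 55000 nM in this assay, so the step from compound 1 to compound 2 is a 1.4-fold lower number from compound 1 to compound 2 (0.13 log units; within the scatter), and the two values sit together. Compound 3 `NS(=O)(=O)c1cc(-c2nnc(CNC(=O)c3ccccc3)o2)c(Cl)cc1SCc1ccccc1` differs from compound 1 by benzamido in place of 4-methylpiperazin-1-yl on a saturated chain carbon bound to an aromatic carbon. Going by the values given here, the one measured step at this same position, a 1.4-fold lower number from compound 1 to compound 2 (0.13 log units; within the scatter), stayed within the scatter, so a step of about a 1.3-fold lower number from compound 1 to compound 3 (0.10 log units; within the scatter) is expected in this assay, no larger than the scatter. Compound 3 is therefore estimated at 60000 nM, within 25000 nM to 150000 nM.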

Compound 3, half-maximal inhibitory concentration: 66000 nM
Estimate against measurement, compound 3: 1.1-fold (0.04 log units) below, within the range that was stated.
By their numbers in this assay, from the lowest: compounds 2, 3 and 1 (each within the scatter of the next).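

Setting benzamido in this place gives, in this assay, a 1.1-fold lower number from compound 1 to compound 3 (0.06 log units; within the scatter), and against azido it gives a 1.2-fold higher number from compound 2 to compound 3 (0.08 log units; within the scatter). The three groups thus sit together even though benzamido brings a six-membered aromatic ring of carbon only and a hydrogen-bond donor, which neither 4-methylpiperazin-1-yl nor azido carries, so neither feature has moved the number beyond the scatter here. Nothing available gives a reason for this result. The compounds shown leave open whether any group on this saturated chain carbon moves the number beyond the scatter. A carboxylic acid or a primary amine there remains an open case.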